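Metabolic stability of quinoline sulfones: predicting a fourth analogue

The source may hold more compounds than are shown below. What is called first, only, known or untested is meant among the compounds shown, and "the series" means these compounds.

Measured compounds:
Compound 1 `COc1ccc(S(=O)(=O)c2cnc3c(F)cccc3c2-c2cccc(F)c2)cc1`: 3.03 mL/min
Compound 2 `COc1ccc(S(=O)(=O)c2cnc3c(F)cccc3c2-c2ccc(Cl)cc2)cc1`: 1.05 mL/min
Compound 3 `O=S(=O)(c1ccc(F)c(Cl)c1)c1cnc2c(F)cccc2c1-c1ccc(Cl)cc1`: 0.01 mL/min

Of the compounds shown here, three sharing a common core have been tested in an ADME assay on microsomes from liver (Homo sapiens) for metabolic stability, tested at 2.5 uM; on this read-out higher numbers stand for fast clearance and lower numbers for slow clearance. Compound 2 `COc1ccc(S(=O)(=O)c2cnc3c(F)cccc3c2-c2ccc(Cl)cc2)cc1` gives 1.05 mL/min in this assay. Compound 1 `COc1ccc(S(=O)(=O)c2cnc3c(F)cccc3c2-c2cccc(F)c2)cc1` differs from it by one change, (3-fluorophenyl in place of 4-chlorophenyl on an aromatic carbon), and the step is a 2.9-fold higher number from compound 2 to compound 1 (0.46 log units; beyond the scatter). Compound 3 `O=S(=O)(c1ccc(F)c(Cl)c1)c1cnc2c(F)cccc2c1-c1ccc(Cl)cc1` differs from compound 2 at a different place, (3-chloro-4-fluorophenyl in place of 4-methoxyphenyl on a sulfonyl sulfur), and that step is a 110-fold lower number from compound 2 to compound 3 (2.02 log units; beyond the scatter). Compound 3 thus gives 0.01 mL/min, the lowest of the three numbers.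

Compound 4 `O=S(=O)(c1ccc(F)c(Cl)c1)c1cnc2c(F)cccc2c1-c1cccc(F)c1` has not yet been measured. It differs from compound 3 by 3-fluorophenyl in place of 4-chlorophenyl on an aromatic carbon. This is the same change that separates compound 2 from compound 1, since the two place descriptions agree word for word; among the compounds shown it occurs twice. Among the compounds with values here, the only precedent is therefore the step from compound 2 to compound 1, which was modest and beyond the scatter. On that basis compound 4 is expected to show a step of a 3.0-fold higher number from compound 3 to compound 4 (0.48 log units; beyond the scatter) in this assay, resting on the step of a 2.9-fold higher number from compound 2 to compound 1 (0.46 log units; beyond the scatter) applied to the number of compound 3. Because compound 3 gives 0.01 mL/min, a very low starting point, the number expected for compound 4 is also very low. Compound 4 is expected to give about 0.03 mL/min in this assay, with a range from 0.01 mL/min to 0.1 mL/min.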

Compound 4, intrinsic clearance in a liver preparation (reported as CLH), per the amount of preparation that the assay uses: 1.23 mL/min
For compound 4 the middle estimate is 41-fold (1.61 log units) below the measured one, outside the stated range (above it).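

In this assay, 3-fluorophenyl in place of 4-chlorophenyl on an aromatic carbon gives a 120-fold higher number from compound 3 to compound 4 (2.09 log units; beyond the scatter), so the change keeps its direction on the second core but not its size: the same change on two cores in this assay, a 2.9-fold higher number (0.46 log units; beyond the scatter) from compound 2 to compound 1 and a 120-fold higher number (2.09 log units; beyond the scatter) from compound 3 to compound 4, 43-fold (1.63 log units) apart, beyond the scatter of two such steps The other change, 3-chloro-4-fluorophenyl in place of 4-methoxyphenyl on a sulfonyl sulfur, behaves in the same way, with a 2.5-fold lower number from compound 1 to compound 4 (0.39 log units; beyond the scatter): the same change on two cores in this assay, a 110-fold lower number (2.02 log units; beyond the scatter) from compound 2 to compound 3 and a 2.5-fold lower number (0.39 log units; beyond the scatter) from compound 1 to compound 4, 43-fold (1.63 log units) apart, beyond the scatter of two such steps Among these four compounds, then, the direction of each step carries from one core to the other, while its size depends on the group at the other place, so neither step could be transferred as a fixed amount; this does not show why the steps differ, nor that the same would hold elsewhere in the series, since the whole gap rests on one set of four compounds and on the low number of compound 3, 0.01 mL/min.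

The compounds shown leave open whether the halogen or its position on the aryl ring drives the larger step, which a 4-fluorophenyl or a 3-chlorophenyl group could help to separate. They also leave open whether a plain phenyl or a pyridine ring on the sulfonyl sulfur would show the same dependence on the other group.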